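The source may report more compounds than this note shows. Statements on the series, on what has been measured and on what is new or still open speak of the compounds shown alone.

Of the compounds shown here, three on the shared core have been read in an in vitro ADME assay on microsomes (Homo sapiens) for metabolic stability; a lower number here means that the compound disappears faster, a higher number that the compound lasts longer. Compound 1 `CCc1nc(NC(CC)CC)c(Cl)nc1-c1ccc(Cl)cc1Cl` gives 0.167 h and compound 2 `CCc1nc(-c2ccc(Cl)cc2Cl)c(CC)nc1NC(C1CC1)C1CC1` gives 0.183 h, two values within the scatter of each other. Compound 3 `CCc1nc(-c2ccc(Cl)cc2Cl)c(OC)nc1NC(CC)CC` gives 0.7 h, the highest of the three numbers and beyond the scatter from both others. Among the measured compounds shown here, no measured pair differs in one place only, so no single change has a measured size yet.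

The next step leads to compound 4 `CCc1nc(-c2ccc(Cl)cc2Cl)c(CC)nc1NC(CC)CC`: ethyl in place of methoxy on an aromatic carbon, with ethyl in place of methoxy on an aromatic carbon. Compound 2 already holds an ethyl at that place, with a different amino group, and stands at 0.183 h. Compound 4 keeps the (pentan-3-yl)amino group of compound 3 and shares it with compound 1, which stands at 0.167 h. For the measured compounds named here, compound 3 is the only measured compound with methoxy, but three compounds support only a weak reading.

In this assay, compound 4 is expected to fall close to compound 2 and well short of compound 3. The expected step, a drop beyond the scatter, is a 2.8-fold lower number from compound 3 to compound 4 (0.45 log units; beyond the scatter). For compound 4 the estimated half-life is 0.25 h, with an expected range from 0.13 h to 0.5 h.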

Compound 4, half-life: 0.283 h
The estimate for compound 4 lay 1.1-fold (0.05 log units) below the measured number; the measured number falls inside the stated range.
By their numbers in this assay, from the lowest: compounds 1, 2 and 4 (each within the scatter of the next); then compound 3.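

Among the compounds shown here, with the (pentan-3-yl)amino group held constant, the aromatic carbon ortho to the 2,4-dichlorophenyl group now has a measured single change in this assay: ethyl in place of methoxy gives a 2.5-fold lower number from compound 3 to compound 4 (0.39 log units; beyond the scatter) and so places a size on this exchange for the first time. Two other single changes stay within the scatter: ethyl in place of chloro at the same carbon gives a 1.7-fold higher number from compound 1 to compound 4 (0.23 log units; within the scatter), and pentan-3-yl in place of dicyclopropylmethyl on the nitrogen gives a 1.5-fold higher number from compound 2 to compound 4 (0.19 log units; within the scatter), so neither exchange separates its pair in this assay. No measurement shown here accounts for the step away from methoxy.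

As far as these compounds go, the methoxy reading rests on one pair, so it remains open whether ethoxy or a longer alkoxy chain at this carbon would keep the higher number seen for compound 3. From the compounds shown here alone, it also remains open whether the methoxy-to-ethyl step keeps its size when dicyclopropylmethyl rather than pentan-3-yl sits on the nitrogen.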